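Notes on a three-compound set and the methoxy-to-hydroxy step

The source may report more compounds than this note shows. Statements on the series, on what has been measured and on what is new or still open speak of the compounds shown alone.

Measured in a functional assay on OVCAR cells (Homo sapiens) for inhibition, read by MTT assay, with a stated time of 48 h; on this read-out higher numbers stand for weaker inhibition of growth and lower numbers for stronger inhibition of growth:
compound 1 `O=[N+]([O-])c1ccc(-c2cc(-c3ccccc3)n[nH]2)cc1`: 7200 nM
compound 2 `COc1ccccc1-c1cc(-c2ccc([N+](=O)[O-])cc2)[nH]n1`: 11700 nM
compound 3 `COc1ccc(-c2cc(-c3ccccc3-c3ccccc3)n[nH]2)cc1`: 670 nM

Compound 3 gives the lowest number of the three in this assay, its gap to compound 1 and to compound 2 lying beyond the scatter. Compound 4 `Oc1ccc(-c2cc(-c3ccccc3-c3ccccc3)n[nH]2)cc1` differs from compound 3 by hydrogen in place of methyl on an oxygen on an aromatic ring. Among the measured compounds shown here, the only paired step measured, a 1.6-fold higher number from compound 1 to compound 2 (0.21 log units; within the scatter), concerns methoxy entering in place of hydrogen at another place and sits within the scatter; no measured pair shows methyl leaving an oxygen. Without a precedent, the expectation for compound 4 is a step of a 1.2-fold higher number from compound 3 to compound 4 (0.08 log units; within the scatter), that is, nothing beyond the scatter. Compound 4 is therefore estimated at 800 nM, with a range of 300 nM to 2500 nM.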

Compound 4, concentration for 50% growth inhibition: 6200 nM
The estimate for compound 4 lay 7.8-fold (0.89 log units) below the measured number; the whole stated range lies below it.
By their numbers in this assay, from the lowest: compound 3; then compounds 4, 1 and 2 (each within the scatter of the next).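

Taking the methyl off this oxygen on an aromatic ring gives the only paired step in the series that clears the scatter in this assay: a 9.3-fold higher number from compound 3 to compound 4 (0.97 log units; beyond the scatter). The methoxy of the 4-methoxyphenyl therefore cannot be exchanged for hydroxy without a clear loss on this read-out, whereas the earlier step, with methoxy entering at another place, showed nothing beyond the scatter. Nothing available explains this step.

Still open, on these data alone, is whether an ethoxy, a longer chain on the oxygen, or an amine in this place would read like methoxy or like hydroxy. Also open, as far as these compounds go, is whether the same change gives a step of this size on other cores.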